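The source may hold more compounds than are shown below. What is called first, only, known or untested is meant among the compounds shown, and "the series" means these compounds.

Of the compounds shown here, two from this series have so far been tested in a functional assay on PANC-1 cells (Homo sapiens) for inhibition, read by MTT assay, with a stated time of 24 h, tested at 10 uM; on this read-out lower numbers stand for less inhibition and higher numbers for more inhibition at the one concentration tested (going by the name of the read-out). Compound 1, `CC(C)=CCC1Cc2c(OCCCNS(=O)(=O)c3ccc(C(F)(F)F)cc3)cc(=O)n(CCCO)c2CC1(C)C`, gives 0% in this assay. Compound 2, `COc1ccc(NC(=O)Oc2cc(=O)n(CCCO)c3c2CC(CC=C(C)C)C(C)(C)C3)cc1`, gives 0% in this assay, which leaves compound 2 level with compound 1 at the digits reported, a gap that lies within the usual scatter of repeated measurements. Within the data shown here, no step between the two measured compounds has been worked out, so their two values show only that neither compound inhibits the cells at the single concentration tested.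

Compound 3, `CC(C)=CCC1Cc2c(OC(=O)Nc3ccc(Cl)cc3)cc(=O)n(CCCO)c2CC1(C)C`, has not yet been measured in this assay. It differs from compound 2 in one place: chloro in place of methoxy on an aromatic carbon. With both measured compounds at the floor of the read-out, there is no footing for expecting a movement in either direction, and the expectation is a change of no size beyond the scatter. The expected change in this assay is a number 3 percentage points higher from compound 2 to compound 3 (within the scatter). Compound 3 is thus expected to give about 3%, with a range from 0% to 18%.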

Compound 3, a percentage reported as inhibition, at one concentration (the size of the read-out at that concentration, not a potency): 0%
Beside the measured number, compound 3's estimate is 3 percentage points above it; measured number inside the range.
By their numbers in this assay, from the lowest: compounds 1, 2 and 3 (each within the scatter of the next).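

In this assay, the 4-methoxyphenyl to 4-chlorophenyl exchange gives no change at the digits printed from compound 2 to compound 3 (within the scatter). Among these compounds, this is the first direct comparison at this position, on an aromatic carbon para to a large group, and it shows that this one replacement does not lift the compound off the floor of the read-out. Because both compounds sit at that floor, the pair cannot show whether methoxy and chloro would differ under conditions where the cells respond; the data offer no explanation for the result.

Still open, on these data alone, is whether a different group at this place, such as an amine or a carboxylic acid, would give a reading clear of the floor. As far as these compounds go, a single-concentration reading is also not a potency, so it remains open whether compound 2 and compound 3 would separate at other concentrations.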